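This account rests on a few compounds, and the source may have more. Where it says the series, first, only, none or still open, it means among the compounds named here.

Working notes on the series. Compound 1 `COc1cc(-c2ccnc3cc(-c4ccc(C(C)(C)C)cc4)nn23)cc(OC)c1OC`, compound 2 `COc1cc(-c2ccnc3cc(-c4ccc(C(C)=O)cc4)nn23)cc(OC)c1OC` and compound 3 `COc1cc(-c2ccnc3cc(-c4ccc5cnn(C)c5c4)nn23)cc(OC)c1OC` share one core and differ only in the aryl group attached to it. In a functional assay on B16-F0 cells (Mus musculus) for inhibition, read by CCK-8 assay, with a stated time of 48 h (on this read-out higher numbers stand for weaker inhibition and lower numbers for stronger inhibition), compound 1 gives only a limit, > 10000 nM. In this assay compound 2 gives 3930 nM, and compound 3 gives 1000 nM. Compound 3 therefore holds the lowest of the two numbers, with compound 2 nearest: a 3.9-fold lower number from compound 2 to compound 3 (0.59 log units; beyond the scatter). Relative to the limit of compound 1, an at least 10-fold lower number from compound 1 to compound 3 (1.00 log units; beyond the scatter) and an at least 2.5-fold lower number from compound 1 to compound 2 (0.40 log units; beyond the scatter); both steps lie beyond the scatter.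

Compound 4 `COc1cc(-c2ccnc3cc(-c4cn(C)c5ccccc45)nn23)cc(OC)c1OC` is not yet measured. It differs from compound 3 by 1-methyl-1H-indol-3-yl in place of 1-methyl-1H-indazol-6-yl on an aromatic carbon. Among the compounds with values here, no measured step swaps one fused bicyclic group for another; the two steps that end at compound 3 each replace a para-substituted phenyl with the indazolyl group, so they bear only loosely on this change. Since the entering and leaving groups are fused bicycles of like size, the step of a 1.5-fold higher number from compound 3 to compound 4 (0.18 log units; within the scatter) is expected to stay within the scatter, with the loss of one acceptor left as an open question. Compound 4 is estimated at 1500 nM in this assay, with a range from 500 nM to 5000 nM.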

Compound 4, half-maximal inhibitory concentration: 185 nM
Beside the measured number, compound 4's estimate is 8.1-fold (0.91 log units) above it; measured number below the stated range.
By their numbers in this assay, from the lowest: compound 4; then compound 3; then compound 2. At a limit, above all of these: compound 1.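

In this assay, the aromatic carbon of the five-membered aromatic ring with 2 nitrogen proves sensitive to the choice between two fused bicyclic groups, not only to the change from a substituted phenyl to a fused bicycle: a 5.4-fold lower number from compound 3 to compound 4 (0.73 log units; beyond the scatter). The gap to the phenyl compounds also widens, with a 21-fold lower number from compound 2 to compound 4 (1.33 log units; beyond the scatter) and an at least 54-fold lower number from compound 1 to compound 4 (1.73 log units; beyond the scatter), so that among these four compounds the two fused bicyclic groups go with the lowest numbers and 1-methyl-1H-indol-3-yl stands first. Compound 1 gives a limit and not a number, so its step is a bound only: the limit of > 10000 nM in this assay, at which 1 of the 4 values shown sits.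

The step from compound 3 to compound 4 changes both the hetero atoms of the five-membered ring and the point of attachment of the bicycle, and the compounds shown do not separate the two; 1-methyl-1H-indazol-3-yl and 1-methyl-1H-indol-6-yl would each change only one of them. Also open, going by these compounds, is what the methyl on the ring nitrogen contributes, which a free 1H-indol-3-yl group or a longer chain such as 1-ethyl-1H-indol-3-yl would address.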